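Smaller Difluorinated Ring in Place of Trifluoromethoxyphenyl

The source may report more compounds than this note shows. Statements on the series, on what has been measured and on what is new or still open speak of the compounds shown alone.

Compound 2 `COc1ccc(C(=O)c2cc(OC)c(OC)c(OC)c2)cc1NC(=O)/C=C/c1cccc(OC(F)(F)F)c1` gives 10200 nM in a functional assay on DU-145 cells (Homo sapiens) for cytotoxicity, read by MTT assay, with a stated time of 72 h (on this read-out higher numbers stand for weaker inhibition and lower numbers for stronger inhibition), the highest of the two numbers measured here, with compound 1 `COc1ccc(C(=O)c2cc(OC)c(OC)c(OC)c2)cc1NC(=O)/C=C/c1ccc(C(F)(F)F)cc1` as its nearest neighbour at 4300 nM. For the measured compounds named here, the single measured step, a 2.4-fold higher number from compound 1 to compound 2 (0.38 log units; beyond the scatter), ran toward a higher number. Compound 3 `COc1ccc(C(=O)c2cc(OC)c(OC)c(OC)c2)cc1NC(=O)/C=C/c1ccc(F)c(F)c1` differs from compound 2 by 3,4-difluorophenyl in place of 3-(trifluoromethoxy)phenyl on a double-bonded chain carbon bound to a double-bonded chain carbon. Going by the values given here, no measured step shows the 3,4-difluorophenyl group, so only that one modest step offers guidance, and it does not point clearly in either direction for this change. Compound 3 is therefore expected to give 6000 nM, within 2000 nM to 18000 nM. That would be an expected step of a 1.7-fold lower number from compound 2 to compound 3 (0.23 log units; within the scatter), close to the scatter.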

Compound 3, half-maximal inhibitory concentration: 10200 nM
Beside the measured number, compound 3's estimate is 1.7-fold (0.23 log units) below it; low and high end bracket the measured number.
By their numbers in this assay, from the lowest: compound 1; then compounds 2 and 3 (each within the scatter of the next).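

In this assay the smaller 3,4-difluorophenyl in place of 3-(trifluoromethoxy)phenyl gives no change at the digits printed from compound 2 to compound 3 (within the scatter), so on this chain carbon, losing heavy atoms and the one hydrogen-bond acceptor leaves the number unmoved. The same group in place of 4-(trifluoromethyl)phenyl gives a 2.4-fold higher number from compound 1 to compound 3 (0.38 log units; beyond the scatter), which leaves compound 1 alone with the lowest number of the three. Nothing measured here explains this pattern. Still open, as far as these compounds go, is whether a plain phenyl ring would match compound 1 or compound 3. Also open, from the compounds shown here alone, is how an amine or a carboxylic acid on this ring would read.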